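This account rests on a few compounds, and the source may have more. Where it says the series, first, only, none or still open, it means among the compounds named here.

Compound 2 `O=C(NO)c1ccc(-c2cn([C@@H]3C[C@H](C(=O)O)N(CCCc4ccccc4)C3)nn2)cc1` carries a hydroxamic acid on one end and a carboxylic acid on a saturated ring at the other. In an assay on Sf9 cells for inhibition of histone deacetylase 11 (Homo sapiens), read by fluorescence, tested at 0.5 uM (a higher number here means more inhibition at the concentration tested (going by the name of the read-out), a lower number less inhibition), compound 2 stops at a limit of the assay, < 10%. Compound 1 `O=C(NO)c1ccc(-c2cn([C@H]3C[C@@H](C(=O)O)N(Cc4ccccc4)C3)nn2)cc1`, a close relative built on the shared core, likewise stops at a limit in this assay, < 10%. Among the compounds with values here, both measured values thus sit together at the same floor, (the limit of < 10% in this assay, at which 2 of the 2 values shown sit), so no step between measured compounds can be sized and no direction of change is known. Compound 3 `O=C(NO)c1ccc(-c2cn([C@H]3C[C@@H](C(=O)O)N(CCCc4ccccc4)C3)nn2)cc1` is the mirror image of compound 2: the two compounds have the same atoms and bonds and differ only in configuration as drawn: 2 of 2 stereo elements differ (all stereocentres are inverted: mirror images); a stereocentre at a saturated ring carbon is drawn R in compound 2 and S in compound 3; a stereocentre at a saturated ring carbon is drawn R in compound 2 and S in compound 3. With nothing to go by but two limits, the step in this assay is expected to be a step that the limit leaves unreadable from compound 2 to compound 3, none beyond the scatter. Compound 3 is therefore estimated at about 5%, within 0% to 20%, and most likely again reported only as a limit.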

Compound 3, a percentage reported as inhibition, at one concentration (the size of the read-out at that concentration, not a potency): 14%
The estimate for compound 3 lay 9 percentage points below the measured number, and the stated range covers the measured number.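

In this assay compound 3 gives 14%, the first result in this set that is a number and not a limit of the assay. Inverting both stereocentres comes to a number at least 4 percentage points higher from compound 2 to compound 3 (that floor lies within the scatter), while phenethyl in place of phenyl on a saturated chain carbon bound to an amine nitrogen in a ring comes to a number at least 4 percentage points higher from compound 1 to compound 3 (that floor lies within the scatter). Neither change can yet be credited with an effect, and the true size of each step stays hidden because only one end of it is a number: the limit of < 10% in this assay, at which 2 of the 3 values shown sit.

As far as these compounds go, all three compounds carry the carboxylic acid on the saturated ring, so what a methyl ester or an amide at that place would do remains open. Also open, from the compounds shown here alone, is whether a longer chain on the ring nitrogen would lift the inhibition clearly beyond the scatter.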